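Chloro for fluoro on the benzyl group and cell tolerance

The source may hold more compounds than are shown below. What is called first, only, known or untested is meant among the compounds shown, and "the series" means these compounds.

Compound 1 `Cc1c(Cc2ccc(F)cc2)c(=O)oc2cc(OCC(O)CN3CCC(C(N)=O)CC3)ccc12` gives 89300 nM in an ADME assay on A549 cells (Homo sapiens) for cytotoxicity, read by CellTiter-Glo; a higher number here means that more compound is tolerated, a lower number that less compound is tolerated. Compound 2 `Cc1c(Cc2ccc(Cl)cc2)c(=O)oc2cc(OCC(O)CN3CCC(C(N)=O)CC3)ccc12` gives 40000 nM in this assay. Compound 3 `Cc1c(Cc2ccc(F)cc2F)c(=O)oc2cc(OCC(O)CN3CCC(C(N)=O)CC3)ccc12` reaches only the assay limit of > 100000 nM in this assay (the limit of > 100000 nM in this assay, at which 1 of the 3 values shown sits).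

The change chloro in place of fluoro on an aromatic carbon made the step of a 2.2-fold lower number from compound 1 to compound 2 (0.35 log units; beyond the scatter). Compound 4 `Cc1c(Cc2ccc(F)cc2Cl)c(=O)oc2cc(OCC(O)CN3CCC(C(N)=O)CC3)ccc12` is not yet measured; it arises from compound 3 by chloro in place of fluoro on an aromatic carbon. The cores of compound 1 and compound 3 differ by fluoro in place of hydrogen on an aromatic carbon. Since the surroundings differ, para to a large group in one case and ortho to a large group and meta to a fluoro group in the other, this is the same kind of change rather than the same change. Compound 4 is expected to show a step of about an at least 1.6-fold lower number from compound 3 to compound 4 (0.22 log units; that floor lies within the scatter), resting on the step of a 2.2-fold lower number from compound 1 to compound 2 (0.35 log units; beyond the scatter) seen for the same kind of change. Compound 4 is therefore estimated at 60000 nM in this assay, between 25000 nM and 150000 nM.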

Compound 4, half-maximal cytotoxic concentration: 90800 nM
Compound 4: the middle estimate sits 1.5-fold (0.18 log units) below what was measured; low and high end bracket the measured number.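

Whether chloro in place of fluoro carries from the core of compound 1 to the core of compound 3 in this assay can be judged only in part: the same change on two cores in this assay, a 2.2-fold lower number (0.35 log units; beyond the scatter) from compound 1 to compound 2 and an at least 1.1-fold lower number (0.04 log units; that floor lies within the scatter) from compound 3 to compound 4; the limit leaves it open whether they differ

The figure for compound 3, > 100000 nM, is a limit of the assay and not a number. The step of an at least 1.1-fold lower number from compound 3 to compound 4 (0.04 log units; that floor lies within the scatter) therefore shows neither that the change carries over nor that it does not, while the other two steps are a 2.3-fold higher number from compound 2 to compound 4 (0.36 log units; beyond the scatter) and a 1.0-fold higher number from compound 1 to compound 4 (0.01 log units; within the scatter).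

On these data alone, what a bromo, methoxy or trifluoromethyl group would do in place of the chloro stays open. So does whether the change keeps its size on a core where neither partner sits at a limit.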